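Aryl amide series: furan-2-yl replaced by 3-nitrophenyl

The source may hold more compounds than are shown below. What is called first, only, known or untested is meant among the compounds shown, and "the series" means these compounds.

compound 1 `O=C(/C=C/c1ccco1)c1ccc(NC(=O)c2cccs2)cc1`: 33000 nM
compound 2 `O=C(/C=C/c1ccco1)c1ccc(NC(=O)c2ccccc2)cc1`: 42000 nM

In a functional assay on HCT-116 cells (Homo sapiens) for cytotoxicity, read by resazurin assay, with a stated time of 48 h (on this read-out lower numbers stand for an effect already at smaller amounts and higher numbers for an effect only at larger amounts of compound), compound 1 gives 33000 nM, the lowest of the two numbers. Compound 2 gives 42000 nM, and the step of a 1.3-fold higher number from compound 1 to compound 2 (0.10 log units; within the scatter) stays within the scatter; it changes only the group on the carbonyl carbon.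

Compound 3 `O=C(/C=C/c1cccc([N+](=O)[O-])c1)c1ccc(NC(=O)c2cccs2)cc1` differs from compound 1 at another site: 3-nitrophenyl in place of furan-2-yl on a double-bonded chain carbon bound to a double-bonded chain carbon. For the measured compounds named here, no measured step bears on this exchange; the only known step, a 1.3-fold higher number from compound 1 to compound 2 (0.10 log units; within the scatter), concerns a different group and was within the scatter. The two measured compounds give no basis for a step beyond the scatter in either direction. Compound 3 is therefore expected to show an estimated step of a 1.1-fold lower number from compound 1 to compound 3 (0.04 log units; within the scatter) in this assay. As far as these compounds go, compound 3 is estimated at 30000 nM, with an expected range from 10000 nM to 90000 nM, the width reflecting that this exchange is untested here.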

Compound 3, half-maximal effective concentration: 2600 nM
For compound 3 the middle estimate is 12-fold (1.06 log units) above the measured one, and the stated range ends above it.
By their numbers in this assay, from the lowest: compound 3; then compounds 1 and 2 (each within the scatter of the next).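

In this assay, the group on the double-bonded chain carbon bound to a double-bonded chain carbon proves to be a site of large change, with a 13-fold lower number from compound 1 to compound 3 (1.10 log units; beyond the scatter). The exchange on the carbonyl carbon gave no such sign, with a 1.3-fold higher number from compound 1 to compound 2 (0.10 log units; within the scatter), so the number depends far more on this position than the first two compounds could show. Nothing at hand accounts for the size of the step from furan-2-yl to 3-nitrophenyl.

As far as these compounds go, the six-membered ring and the nitro group enter together, so it remains open which of them carries the step; a plain phenyl, or an amine in place of the nitro group, would separate the two. From the compounds shown here alone, it also remains open whether the exchange of thiophen-2-yl for phenyl on the carbonyl carbon stays within the scatter when 3-nitrophenyl is present.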